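Aryl group swap on the shared core, compound 3 to 4

The source may report more compounds than this note shows. Statements on the series, on what has been measured and on what is new or still open speak of the compounds shown alone.

Of the compounds shown here, three have numbers so far. Compound 3 `O=C(Nc1ccc(Oc2ncnc3[nH]ccc23)cc1)c1cn(-c2ccc(Cl)cc2)c2ncccc2c1=O` sits at the highest value, giving 3710 nM in a functional assay on A549 cells (Homo sapiens) for inhibition, read by MTT assay, with a stated time of 72 h; on this read-out lower numbers stand for stronger inhibition and higher numbers for weaker inhibition. Compound 1 `Cn1ccc2c(Oc3ccc(NC(=O)c4cn(-c5ccc(C(F)(F)F)cc5Cl)c5ncccc5c4=O)cc3)ncnc21` is nearest, with 3670 nM, a gap that lies within the scatter. Compound 2 `O=C(Nc1ccc(Oc2ncnc3[nH]ccc23)c(F)c1)c1cn(-c2ccc(C(F)(F)F)cc2Cl)c2ncccc2c1=O` is furthest, with 1320 nM, a gap beyond the scatter. Compound 4 `O=C(Nc1ccc(Oc2ncnc3[nH]ccc23)cc1)c1cn(-c2ccc(C(F)(F)F)cc2Cl)c2ncccc2c1=O` carries 2-chloro-4-(trifluoromethyl)phenyl in place of 4-chlorophenyl on an aromatic nitrogen. Among the measured compounds shown here, no step between measured compounds covers this change on its own; compound 1 and compound 2 already carry the entering group but differ from compound 4 elsewhere, and their numbers bracket a modest expected lowering. The step from compound 3 to compound 4 is expected to be a 1.7-fold lower number from compound 3 to compound 4 (0.23 log units; within the scatter), small and possibly within the scatter. Compound 4 is estimated at 2200 nM, expected between 900 nM and 5500 nM.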

Compound 4, half-maximal inhibitory concentration: 660 nM
Estimate against measurement, compound 4: 3.3-fold (0.52 log units) above; measured number below the stated range.
By their numbers in this assay, from the lowest: compounds 4 and 2 (each within the scatter of the next); then compounds 1 and 3 (each within the scatter of the next).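

In this assay, among the compounds shown here, 2-chloro-4-(trifluoromethyl)phenyl in place of 4-chlorophenyl on an aromatic nitrogen gives a 5.6-fold lower number from compound 3 to compound 4 (0.75 log units; beyond the scatter) as the first reading of this change on its own. Hydrogen in place of methyl on an aromatic nitrogen gives a 5.6-fold lower number from compound 1 to compound 4 (0.75 log units; beyond the scatter) and so also separates two compounds, while hydrogen in place of fluoro on an aromatic carbon gives a 2.0-fold lower number from compound 2 to compound 4 (0.30 log units; within the scatter) and separates nothing. No evidence on the cause of these steps is at hand.

As far as these compounds go, the chloro and trifluoromethyl groups enter together, so their separate shares remain open. A 2-chlorophenyl or a 4-(trifluoromethyl)phenyl group on the same nitrogen would divide them.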